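Sulfanyl for chloro on the core of compound 1

The source may report more compounds than this note shows. Statements on the series, on what has been measured and on what is new or still open speak of the compounds shown alone.

Compound 1 `CC(=O)OCCOn1cnc2c(Cl)nc(N)nc21` is known in a functional assay on HEp-2 cells (Homo sapiens) for inhibition (a lower number here means a stronger inhibitor, a higher number a weaker inhibitor), only as a limit, > 500000 nM, so it stands at the limit of > 500000 nM in this assay, at which 2 of the 3 values shown sit, rather than at a number. Compound 3 `Nc1nc(I)nc2c1ncn2OCCO` likewise gives only a limit, > 500000 nM, in this assay. For the measured compounds named here, compound 2 `CC(=O)OCCOn1cnc2c(Cl)nc(I)nc21` gives 56200 nM in this assay, and the step of an at least 8.8-fold lower number from compound 1 to compound 2 (0.94 log units; beyond the scatter) is the one measured change. Compound 4 `CC(=O)OCCOn1cnc2c(S)nc(N)nc21` differs from compound 1 by sulfanyl in place of chloro on an aromatic carbon; the measured step concerns a different carbon and different groups, so it does not bear on this change. With compound 1 at a limit, the expectation for compound 4 in this assay is a number near that limit, 400000 nM with a range from 50000 nM to 1000000 nM, which would mean a step of an at least 1.2-fold lower number from compound 1 to compound 4 (0.09 log units; that floor lies within the scatter), with a limit again quite likely.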

Compound 4, half-maximal inhibitory concentration: 4900 nM
For compound 4 the middle estimate is 82-fold (1.91 log units) above the measured one; measured number below the stated range.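

In this assay, the carbon opposite the ring nitrogen proves sensitive to its substituent: sulfanyl in place of chloro gives an at least 100-fold lower number from compound 1 to compound 4 (2.00 log units; beyond the scatter). The earlier step changed a different carbon, so this shows that the number can also move strongly with the amino group kept. The size of the step is only a floor, since compound 1 stands at a limit of the assay: the limit of > 500000 nM in this assay, at which 2 of the 4 values shown sit.

Going by these compounds, it remains open whether a hydroxyl, an amine or a methylsulfanyl group on this carbon would give a similar step. Also open, on these data alone, is how sulfanyl behaves with iodo in place of amino.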